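Swapping an amide amine for hydroxypyrrolidine: stability outlook

A few compounds are considered here, and "the series" means these few. Any claim that something is new, unique, unknown or untested is made for them only; others in the source may bear on it.

Measured compounds in an ADME assay on microsomes from liver (Rattus norvegicus) for metabolic stability, read by LC-MS, using NADPH, with a stated time of 30 min, tested at 0.1 uM, in the presence of a further agent that is not named here; on this read-out lower numbers stand for a less stable compound and higher numbers for a more stable compound:
- Compound 1 `Nc1ccc(-c2cnc(N)c(-c3ccc(N)nc3)n2)cn1` sits at a limit of the assay, > 90%.
- Compound 2 `Nc1ncc(-c2ccc(C(=O)N3CC[C@H](O)C3)cc2)nc1-c1ccc(C(F)(F)F)cc1` also sits at a limit, > 90%.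
- Compound 3 `NC(=O)c1ccc(-c2cnc(N)c(-c3ccc(C(F)(F)F)cc3)n2)cc1` likewise sits at a limit, > 90%.

All three values are therefore limits rather than numbers, and compound 3 stands at the same limit as the other two. The change now followed is from compound 3 to compound 4 `Nc1ncc(-c2ccc(C(=O)N3CC[C@@H](O)C3)cc2)nc1-c1ccc(C(F)(F)F)cc1`: 3-hydroxypyrrolidin-1-yl in place of amino on a carbonyl carbon. For the measured compounds named here, the only measured step of this kind runs the other way, a step that the two limits leave unreadable from compound 2 to compound 3, and it gives no readable size because of the limit of > 90% in this assay, at which 3 of the 3 values shown sit. Going by the values given here, no step here shows whether exchanging amino and 3-hydroxypyrrolidin-1-yl on the carbonyl carbon shifts the read-out in either direction beyond the scatter.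

On this basis compound 4 is expected to stay where compound 3 stands, and the step that the limit leaves unreadable from compound 3 to compound 4 is estimated as none beyond the scatter. Compound 4 is therefore estimated at 93% in this assay, within a range from 80% to 100%, most likely again reported only as a limit.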

Compound 4, percent of the compound remaining: > 90%
Compound 4: a limit, no number; the forecaster's own chance of this, stated with the estimate: 0.8%; the middle value lies beyond the limit too.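

Compound 4 gives only a limit, so neither its step from compound 3 nor its step from compound 2 can be read: the limit of > 90% in this assay, at which 4 of the 4 values shown sit.

The compounds shown leave open whether 3-hydroxypyrrolidin-1-yl in place of amino on the carbonyl carbon, or the drawn configuration at its stereocentre, shifts the percent of compound remaining at all.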